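A few compounds are considered here, and "the series" means these few. Any claim that something is new, unique, unknown or untested is made for them only; others in the source may bear on it.

Of the compounds shown here, three built on one shared core have so far been measured in an assay on cells for inhibition of HSP60/HSP10 (Homo sapiens), with a stated time of 60 min; on this read-out lower numbers stand for stronger inhibition and higher numbers for weaker inhibition. Compound 1, `O=S(=O)(Nc1ccc(-c2nc3ccccc3o2)cc1)c1ccccc1Cl`, gives only a limit in this assay, > 100000 nM, so no number is known for it. Compound 2, `O=S(=O)(Nc1ccc(-c2nc3ccccc3o2)cc1)c1cccc(C(F)(F)F)c1`, gives 57000 nM in this assay. Compound 3, `O=S(=O)(Nc1ccc(-c2nc3ccccc3o2)cc1)c1ccc(F)cc1`, gives 73000 nM in this assay. Among the two numbers shown, compound 3 stands at the higher one, and its nearest neighbour is compound 2, whose number lies within the scatter of it; the third value is a limit and cannot be ranked. Among the compounds with values here, the only measured single change, an at least 1.3-fold lower number from compound 1 to compound 3 (0.13 log units; that floor lies within the scatter), has a floor that lies within the scatter, because one of its two ends is the limit of > 100000 nM in this assay, at which 1 of the 3 values shown sits; it therefore shows no clear direction.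

Compound 4, `Cc1cccc(S(=O)(=O)Nc2ccc(-c3nc4ccccc4o3)cc2)c1`, is the compound still to be measured. Its difference from compound 3 is 3-methylphenyl in place of 4-fluorophenyl on a sulfonyl sulfur. Within the data shown here, no measured step swaps these two rings, and the one step that does touch the ring on the sulfonyl sulfur gave nothing beyond the scatter. For this change, then, no shift beyond the scatter is expected, and the step of a 1.0-fold lower number from compound 3 to compound 4 (0.02 log units; within the scatter) is the estimated outcome. Compound 4 is expected to give about 70000 nM in this assay, with a range from 25000 nM to 200000 nM.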

Compound 4, half-maximal inhibitory concentration: > 100000 nM
Compound 4 ended at the assay's limit (the forecaster's own chance of this, stated with the estimate: 30%); middle value at least 1.4-fold (0.15 log units) away from the limit.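

In this assay, 3-methylphenyl in place of 4-fluorophenyl on the sulfonyl sulfur gives an at least 1.3-fold higher number from compound 3 to compound 4 (0.13 log units; that floor lies within the scatter), and methyl in place of trifluoromethyl on an aromatic carbon gives an at least 1.7-fold higher number from compound 2 to compound 4 (0.24 log units; that floor lies within the scatter); each floor lies within the scatter, so neither step shows a clear direction, although the true size of each could be larger. What is new is that a second ring at this position gives only a limit, and the two rings that give numbers, in compound 2 and compound 3, are the ones carrying fluorine, a split that these steps cannot yet establish. The step between the two compounds that both end at a limit cannot be read, and the comparison across the series stays coarse: the limit of > 100000 nM in this assay, at which 2 of the 4 values shown sit.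

Going by these compounds, whether an amine or a carboxylic acid on the ring on the sulfonyl sulfur would give a number clearly lower than those of compound 2 and compound 3 stays open. Also open, on these data alone, is how far the true values of compound 1 and compound 4 lie past their limits.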